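A few compounds are considered here, and "the series" means these few. Any claim that something is new, unique, unknown or untested is made for them only; others in the source may bear on it.

Compound 1 `N#Cc1ccc(-c2nc3sccn3c2/C=N/OCc2ccc(Cl)c(Cl)c2)cc1`: 3400 nM
Compound 2 `Clc1ccccc1CO/N=C/c1c(-c2ccc3ccccc3c2)nc2occn12`: 1100 nM

Within the data shown here, in an assay on HepG2 cells for agonist activity at nuclear receptor subfamily 1 group I member 3 (Homo sapiens), read by a luciferase reporter, with a stated time of 23 h (on this read-out lower numbers stand for an effect already at smaller amounts and higher numbers for an effect only at larger amounts of compound), compound 1 gives 3400 nM, the higher of the two numbers measured so far. Compound 2 gives 1100 nM, a lower number, and that gap is beyond the usual scatter. Compound 3 `Clc1ccc(CO/N=C/c2c(-c3ccc4ccccc4c3)nc3sccn23)cc1Cl` has not yet been measured. It differs from compound 1 in one place: naphthalen-2-yl in place of 4-cyanophenyl on an aromatic carbon. Compound 2, which also carries naphthalen-2-yl, gives 1100 nM, the lower number. On that basis a modest move toward lower numbers is expected, estimated as a 3.4-fold lower number from compound 1 to compound 3 (0.53 log units; beyond the scatter). Compound 3 is expected to give about 1000 nM, within a range from 300 nM to 3500 nM.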

Compound 3, half-maximal effective concentration: 380 nM
Compound 3: the middle estimate sits 2.6-fold (0.42 log units) above what was measured; the measured number falls inside the stated range.
By their numbers in this assay, from the lowest: compound 3; then compound 2; then compound 1.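

In this assay, placing naphthalen-2-yl instead of 4-cyanophenyl on this aromatic carbon gives an 8.9-fold lower number from compound 1 to compound 3 (0.95 log units; beyond the scatter) with the rest of the molecule unchanged. Among these compounds, compounds 1 and 2 differ in more than one place, so only this pair isolates the change at this position, and the step is beyond the usual scatter. The data shown give no reason for the step. Going by these compounds, it remains open whether the nitrile alone matters or the second aromatic ring does. A phenyl ring without a nitrile, or one carrying an amine or a carboxylic acid, would help separate these possibilities.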